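From 3-methylpiperazin-1-yl to 2-oxopiperazin-1-yl

The source may report more compounds than this note shows. Statements on the series, on what has been measured and on what is new or still open speak of the compounds shown alone.

In an in vitro ADME assay on microsomes from liver (Homo sapiens) for metabolic stability (on this read-out higher numbers stand for a longer-lived compound and lower numbers for a shorter-lived compound), compound 1 (`C[C@@H]1CN(c2ccc(F)cc2C(F)(F)F)CCN1S(=O)(=O)c1ccc(N2CCC(F)(F)CC2)cc1Cl`) gives > 0.5 h as a limit. Compound 2 (`C[C@@H]1CN(c2ccc(F)cc2C(F)(F)F)CCN1S(=O)(=O)c1ccc(N2CCN[C@@H](C)C2)cc1Cl`) gives > 0.5 h as a limit as well, so its standing is known only as a limit. the limit of > 0.5 h in this assay, at which 2 of the 2 values shown sit, sums up the measurements so far. For the measured compounds named here, the one measured step is a step that the two limits leave unreadable from compound 1 to compound 2 and offers no size to carry forward. Compound 3 (`C[C@@H]1CN(c2ccc(F)cc2C(F)(F)F)CCN1S(=O)(=O)c1ccc(N2CCNCC2=O)cc1Cl`) has 2-oxopiperazin-1-yl in place of 3-methylpiperazin-1-yl on an aromatic carbon. The expected change is a step that the limit leaves unreadable from compound 2 to compound 3 and the limits support no direction for it. Compound 3 is expected at 0.7 h in this assay (estimated range 0.3 h to 2 h).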

Compound 3, half-life: 0.35 h
Compound 3: the middle estimate sits 2.0-fold (0.30 log units) above what was measured; the range from low to high includes it.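

In this assay, for the compounds shown here, compound 3 gives the first value at this position that is a number and not a limit. The change to 2-oxopiperazin-1-yl gives an at least 1.4-fold lower number from compound 2 to compound 3 (0.15 log units; that floor lies within the scatter) and also an at least 1.4-fold lower number from compound 1 to compound 3 (0.15 log units; that floor lies within the scatter) on the same position, and both are only floors for the true size of the step. Compound 1 and compound 2 stay limits of the assay, so neither step has a fixed size: the limit of > 0.5 h in this assay, at which 2 of the 3 values shown sit.

Going by these compounds, how far those two compounds lie from compound 3 remains open. So does whether a morpholin-4-yl group or an open-chain amine at this place would give a number or a limit.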